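This account rests on a few compounds, and the source may have more. Where it says the series, first, only, none or still open, it means among the compounds named here.

Of the compounds shown here, two sharing one core have so far been measured in a functional assay on HT-29 cells (Homo sapiens) for cytotoxicity, read by sulforhodamine B assay, with a stated time of 2 days, tested at 100 uM; a lower number here means less inhibition, a higher number more inhibition at the concentration tested (going by the name of the read-out). Compound 1 `CCCc1nc2c(-c3ccc(Cl)cc3)n[nH]c2c(=O)n1NC(=O)c1ccccc1` carries a propyl chain on the core and a benzoyl group on the amide nitrogen; in this assay compound 1 gives 91.1%. Compound 2 `O=C(Nn1c(CCC2CCCC2)nc2c(-c3ccc(Cl)cc3)n[nH]c2c1=O)c1ccccc1` differs only in the chain, and in this assay compound 2 gives 87.3%. For the measured compounds named here, the one step measured, a number 3.8 percentage points lower from compound 1 to compound 2 (within the scatter), shows that the two numbers lie within the scatter of each other, so the chain change left the read-out essentially where it was.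

Compound 3 `CC(C)(C)c1ccc(C(=O)Nn2c(CCC3CCCC3)nc3c(-c4ccc(Cl)cc4)n[nH]c3c2=O)cc1` is the next member, differing from compound 2 by tert-butyl in place of hydrogen on an aromatic carbon. Going by the values given here, no measured step touches the benzoyl ring, so the only step available, the one from compound 1 to compound 2, bears on it merely as a sign that the series sits near the top of the range and that one change left the number level. On that basis no step beyond the scatter is expected in this assay. Compound 3 is therefore expected to give 84%, with a range from 62% to 95%. The implied step, a number 3.3 percentage points lower from compound 2 to compound 3 (within the scatter), is estimated to stay within the scatter.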

Compound 3, a percentage reported as inhibition, at one concentration (the size of the read-out at that concentration, not a potency): 76.8%
Compound 3: middle estimate off by 7.2 percentage points, on the high side, within the range that was stated.
By their numbers in this assay, from the lowest: compound 3; then compounds 2 and 1 (each within the scatter of the next).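

In this assay, for the compounds shown here, tert-butyl in place of hydrogen on an aromatic carbon of the benzoyl ring, para to a large group, gives a number 10.5 percentage points lower from compound 2 to compound 3 (beyond the scatter) and so marks the first modest change. Going by these compounds alone, the one earlier step concerned the chain and stayed within the scatter, whereas this one shows that the number responds to a change on the benzoyl ring, although compound 3 still gives 76.8% at the tested concentration. Nothing measured here accounts for the lower number.

With a single substituent at this place, the compounds shown leave open whether the step follows from tert-butyl in particular or would also appear with a methyl group, a chlorine atom, an amine or a carboxylic acid in the same position. They also leave open whether tert-butyl would produce a similar step on the propyl-bearing compound 1, where the chain differs from that of compound 2, or whether this step is specific to the cyclopentyl-bearing chain.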